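This account rests on a few compounds, and the source may have more. Where it says the series, first, only, none or still open, it means among the compounds named here.

Compound 1 `CN(C)CCn1cnnc1-c1cc(Oc2ccc(NC(=O)Nc3ccc(F)c(F)c3)cc2F)ccn1`: 9050 nM in a functional assay on NCI-H460 cells (Homo sapiens) for antiproliferative activity, read by MTT assay, with a stated time of 72 h; on this read-out lower numbers stand for stronger inhibition and higher numbers for weaker inhibition. Compound 2 `CCN(CC)CCn1cnnc1-c1cc(Oc2ccc(NC(=O)Nc3ccccc3C(F)(F)F)cc2F)ccn1`: > 50000 nM.

For compound 2 this value is only a limit of this assay and not a number (the limit of > 50000 nM in this assay, at which 1 of the 2 values shown sits). Compound 3 `CCN(CC)CCn1cnnc1-c1cc(Oc2ccc(NC(=O)Nc3ccc(F)c(F)c3)cc2F)ccn1` has not yet been measured. Going from compound 2 to compound 3, the change is 3,4-difluorophenyl in place of 2-(trifluoromethyl)phenyl on an amide-type nitrogen. The other compound bearing the same 3,4-difluorophenyl group, compound 1, gives 9050 nM in this assay, so compound 3 is expected to land near that, a step of an at least 4.1-fold lower number from compound 2 to compound 3 (0.61 log units; beyond the scatter) toward stronger inhibition. The estimate for compound 3 is 12000 nM, with a range of 3500 nM to 45000 nM.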

Compound 3, half-maximal inhibitory concentration: 14900 nM
Beside the measured number, compound 3's estimate is 1.2-fold (0.09 log units) below it, and the stated range covers the measured number.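

On the amide-type nitrogen, 3,4-difluorophenyl in place of 2-(trifluoromethyl)phenyl gives a measurable number in this assay, with an at least 3.3-fold lower number from compound 2 to compound 3 (0.52 log units; beyond the scatter). The value of compound 2 is a limit of the assay and not a number, so the true step could be larger: the limit of > 50000 nM in this assay, at which 1 of the 3 values shown sits. At the other end of the molecule, diethylamino in place of dimethylamino gives a 1.6-fold higher number from compound 1 to compound 3 (0.22 log units; within the scatter), so the two amines cannot be told apart here.

Still open, going by these compounds, is how a plain phenyl or a 4-chlorophenyl would behave on that nitrogen. Also open, on these data alone, is whether a ring amine such as morpholine on the chain would differ from diethylamino.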